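The source may hold more compounds than are shown below. What is called first, only, known or untested is meant among the compounds shown, and "the series" means these compounds.

Compound 2 `COc1ccc(-c2cnc(NC(=O)c3ccn[nH]3)n2C)cc1` is the starting point of this comparison. In a toxicity assay on THP-1 cells (Homo sapiens) for inhibition (on this read-out higher numbers stand for lower toxicity in this test and lower numbers for higher toxicity in this test), compound 2 does not give a number but only a limit, > 100000 nM, as recorded by the limit of > 100000 nM in this assay, at which 1 of the 3 values shown sits, in the set. Compound 3 `COc1ccc(-c2cnc(NC(=O)c3cc(-c4ccccn4)n[nH]3)n2C)cc1` carries pyridin-2-yl in place of hydrogen on an aromatic carbon, and in this assay compound 3 likewise stops at a limit, >= 50000 nM, marked by the limit of >= 50000 nM in this assay, at which 1 of the 3 values shown sits, here. The step that the two limits leave unreadable from compound 2 to compound 3 therefore cannot be read in size. Compound 1 `Cn1c(-c2cccc(Br)c2)cnc1NC(=O)c1ccc(F)cc1`, whose amide-linked aromatic ring carries fluorine while its other ring carries bromine, also reaches only a limit in this assay, > 50000 nM, shown by the limit of > 50000 nM in this assay, at which 1 of the 3 values shown sits, in the data. Compound 4 `COc1ccc(-c2cnc(NC(=O)c3cccc(F)c3)n2C)cc1` has not been measured; it differs from compound 2 by 3-fluorophenyl in place of 1H-pyrazol-5-yl on a carbonyl carbon. Among the compounds with values here, no measured step covers this exchange, and every measured value rests at a limit, so nothing points to toxicity in this range. The expectation for compound 4 is therefore that it stays at or near a limit as well, with an expected step of an at least 1.2-fold lower number from compound 2 to compound 4 (0.09 log units; that floor lies within the scatter) that should not exceed the usual scatter. Compound 4 is estimated at 80000 nM, with a likely range from 30000 nM to 150000 nM, most probably reported only as a limit.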

Compound 4, half-maximal cytotoxic concentration: > 100000 nM
Compound 4: no number, only a limit (the forecaster's own chance of this, stated with the estimate: 80%); middle value at least 1.2-fold (0.09 log units) away from the limit.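

In this assay compound 4 gives only a limit, > 100000 nM. Within the data shown here, compound 2 likewise gives only a limit, so no step between compound 2 and compound 4 can be read. The compounds shown leave open at what concentration, if any, each would become toxic to these cells, and whether 3-fluorophenyl in place of 1H-pyrazol-5-yl changes that concentration.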